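The source may report more compounds than this note shows. Statements on the series, on what has been measured and on what is new or still open speak of the compounds shown alone.

Series notes, cytotoxicity read-out. Three compounds carry a number in a functional assay on MCF7 cells (Homo sapiens) for cytotoxicity, read by MTT assay, with a stated time of 24 h; on this read-out higher numbers stand for weaker inhibition and lower numbers for stronger inhibition. Compound 1 `CCOc1ccccc1N1CCN(C(=S)SCc2nc3cc(Cl)c(Cl)cc3[nH]2)CC1` gives 16200 nM in this assay. Compound 2 `CN1CCN(CCCSc2nc3ccccc3[nH]2)CC1` gives 77900 nM. Compound 3 `c1ccc2[nH]c(SCCCN3CCNCC3)nc2c1` gives 91700 nM. Compound 3 stands highest of the three; its nearest neighbour is compound 2, with the step of a 1.2-fold higher number from compound 2 to compound 3 (0.07 log units; within the scatter) inside the scatter, while the gap to compound 1 lies beyond the scatter. Among the measured compounds shown here, compound 1 differs from compound 3 in several places at once, so no single step connects those two.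

Compound 4 `COc1ccc(N2CCN(CCCSc3nc4ccccc4[nH]3)CC2)cc1` is not yet measured. It differs from compound 3 by 4-methoxyphenyl in place of hydrogen on an amine nitrogen in a ring. For the measured compounds named here, the only measured step at that same ring nitrogen is a 1.2-fold higher number from compound 2 to compound 3 (0.07 log units; within the scatter), a small exchange of hydrogen for methyl with no effect beyond the scatter; it gives no direction for a much larger group. Going by the values given here, compound 1 is the one compound with an aryl group on that ring nitrogen, and its number sits well below that of compound 3, but its other differences mean this cannot be read as a step. Compound 4 is therefore expected to show a somewhat lower number, with wide uncertainty. The expected step in this assay is a 2.6-fold lower number from compound 3 to compound 4 (0.42 log units; beyond the scatter). Compound 4 is estimated at 35000 nM, with a range from 10000 nM to 120000 nM.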

Compound 4, half-maximal inhibitory concentration: 6840 nM
Compound 4: the middle estimate sits 5.1-fold (0.71 log units) above what was measured; measured number below the stated range.
By their numbers in this assay, from the lowest: compound 4; then compound 1; then compounds 2 and 3 (each within the scatter of the next).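

In this assay, the amine nitrogen in the six-membered non-aromatic ring responds strongly to what it carries: 4-methoxyphenyl in place of hydrogen gives a 13-fold lower number from compound 3 to compound 4 (1.13 log units; beyond the scatter), and 4-methoxyphenyl in place of methyl gives an 11-fold lower number from compound 2 to compound 4 (1.06 log units; beyond the scatter), both large steps, while hydrogen in place of methyl gave only a 1.2-fold higher number from compound 2 to compound 3 (0.07 log units; within the scatter). Among the compounds shown here, the two small groups therefore gave no hint of what this position can do, and an aryl group on this nitrogen now has an effect that can be read as a change in one place, which no earlier pair allowed. Nothing measured here accounts for the size of these steps.

The compounds shown leave open whether the steps belong to the six-membered aromatic ring itself or to the methoxy group on it: a plain phenyl on the same nitrogen is not among them. They also leave open how a benzyl group on that nitrogen would compare, and whether the steps would hold in this assay on a core carrying two chlorines.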